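The source may report more compounds than this note shows. Statements on the series, on what has been measured and on what is new or still open speak of the compounds shown alone.

Compound 1 `C=CCOC(=O)C1=C(C)NC(C)=C(C(=O)OC)C1c1cccc([N+](=O)[O-])c1` and compound 2 `C=CCOC(=O)C1=C(C)NC(C)=C(C(=O)OCC)C1c1cccc([N+](=O)[O-])c1` have both been measured in a functional assay on HEK293 cells for antagonist activity at Voltage-dependent L-type calcium channel subunit alpha-1C (Oryctolagus cuniculus), read by FLIPR; on this read-out lower numbers stand for stronger inhibition and higher numbers for weaker inhibition. Compound 1 gives 15 nM, and compound 2 gives 25 nM; the step of a 1.7-fold higher number from compound 1 to compound 2 (0.22 log units; within the scatter) leaves the two standing level. Compound 3 `C#CCCOC(=O)C1=C(C)NC(C)=C(C(=O)OC)C1c1cccc([N+](=O)[O-])c1` has not been measured; it differs from compound 1 by propargyl in place of vinyl on a saturated chain carbon bound to an oxygen next to a carbonyl group. Within the data shown here, the only measured step at this place, a 1.7-fold higher number from compound 1 to compound 2 (0.22 log units; within the scatter), changed the number by less than the scatter, so no step beyond the scatter is expected here either. Compound 3 is therefore estimated at 15 nM, with a range from 6 nM to 40 nM. The expected step is no change at the digits printed from compound 1 to compound 3 (within the scatter).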

Compound 3, half-maximal inhibitory concentration: 31 nM
Compound 3: the middle estimate sits 2.1-fold (0.32 log units) below what was measured, and the stated range covers the measured number.
By their numbers in this assay, from the lowest: compounds 1, 2 and 3 (each within the scatter of the next, the first and the last beyond it).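

Among these compounds, the change from vinyl to propargyl on a saturated chain carbon bound to an oxygen next to a carbonyl group gives the first step beyond the scatter in this assay, namely a 2.1-fold higher number from compound 1 to compound 3 (0.32 log units; beyond the scatter). This group therefore does not tolerate every change without effect, although the weakening is modest. Nothing available explains the shift.

The compounds shown change the triple bond and the carbon count together, leaving open which of the two matters. On these data alone, how an amine, a carboxylic acid or a longer chain would read here also remains open.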